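Amine side chain: 4-chlorophenyl to phenethyl

A few compounds are considered here, and "the series" means these few. Any claim that something is new, unique, unknown or untested is made for them only; others in the source may bear on it.

In a functional assay on MCF7 cells (Homo sapiens) for inhibition (a higher number here means a weaker inhibitor, a lower number a stronger inhibitor), three compounds with a shared core have been measured. Compound 1 `O=C(NO)c1ccc(-c2ccc(CNCc3ccccc3Cl)cn2)s1` gives 110 nM, compound 2 `O=C(NO)c1ccc(-c2ccc(CNCc3ccc(Cl)cc3)cn2)s1` gives 130 nM and compound 3 `O=C(NO)c1ccc(-c2ccc(CNCc3ccc(-c4ccccc4)cc3)cn2)s1` gives 150 nM. Compound 2 therefore stands within the scatter of both other compounds, and the three numbers form a single group.

Compound 4 `O=C(NO)c1ccc(-c2ccc(CNCCCc3ccccc3)cn2)s1`, not yet measured, keeps the shared core and differs from compound 2 as follows: phenethyl in place of 4-chlorophenyl on a saturated chain carbon bound to an amine nitrogen. In words, this is phenethyl in place of 4-chlorophenyl on a saturated chain carbon bound to an amine nitrogen.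

Among the compounds with values here, two measured steps bear on this change. Putting 4-chlorophenyl in place of 2-chlorophenyl at this same place gives a 1.2-fold higher number from compound 1 to compound 2 (0.07 log units; within the scatter). Putting phenyl in place of chloro on an aromatic carbon gives a 1.2-fold higher number from compound 2 to compound 3 (0.06 log units; within the scatter). Both steps are small and lie within the scatter. Within the data shown here, no measured compound carries phenethyl, however, so these steps offer only limited guidance and the range is kept wide.

The expected step is a 1.1-fold higher number from compound 2 to compound 4 (0.03 log units; within the scatter), which means none beyond the scatter. Compound 4 is expected at 140 nM in this assay, with an estimated range from 60 nM to 350 nM.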

Compound 4, half-maximal inhibitory concentration: 120 nM
Beside the measured number, compound 4's estimate is 1.2-fold (0.07 log units) above it, within the range that was stated.
By their numbers in this assay, from the lowest: compounds 1, 4, 2 and 3 (each within the scatter of the next).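

In this assay, phenethyl in place of 4-chlorophenyl on a saturated chain carbon bound to an amine nitrogen gives a 1.1-fold lower number from compound 2 to compound 4 (0.03 log units; within the scatter), and phenethyl in place of 2-chlorophenyl at the same place gives a 1.1-fold higher number from compound 1 to compound 4 (0.04 log units; within the scatter). The earlier compounds varied only the substituent on a ring, whereas this change removes the chlorine and extends the chain carrying the ring, and both steps still lie within the scatter, so this position tolerates a change of chain length as well as a change of ring substituent among the compounds shown. No supporting measurement bears on this result, so the series gives no account of it.

All the groups shown at this position carry a six-membered aromatic ring of carbon only and no net charge, so it remains open whether a pyridyl ring, a carboxylic acid or a further amine there would stay within the scatter of these compounds. From the compounds shown here alone, it is also open how far the chain can grow, since a longer chain than phenethyl, or a plain alkyl chain with no ring at all, would test the limits of this tolerance.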